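Adding a sulfamoyl group to a weak cell growth inhibitor

The source may hold more compounds than are shown below. What is called first, only, known or untested is meant among the compounds shown, and "the series" means these compounds.

Of the compounds shown here, two have been tested in a functional assay on cells (Leukemia cell, Homo sapiens) for cytotoxicity, read by sulforhodamine B assay, with a stated time of 48 h; on this read-out lower numbers stand for stronger inhibition of growth and higher numbers for weaker inhibition of growth. Compound 1 `NS(=O)(=O)c1ccc(-n2nc(-c3ccc(Cl)cc3)cc2-c2cc(O)ccc2O)cc1` gives 5030 nM. Compound 2 `O=C1C=CC(=O)C(c2cc(-c3ccc(Cl)cc3)nn2-c2ccccc2)=C1` gives 27800 nM, the higher of the two numbers, which sets it a gap beyond the usual scatter apart from compound 1. The two differ in more than one place, so their gap cannot be tied to a single change.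

Compound 3 `NS(=O)(=O)c1ccc(-n2nc(-c3ccc(Cl)cc3)cc2C2=CC(=O)C=CC2=O)cc1` has not yet been measured. It differs from compound 2 in one place only: sulfamoyl in place of hydrogen on an aromatic carbon. Compound 1 carries the same sulfamoyl group, though on a core that differs from the shared core of compounds 2 and 3 in a further place, and its lower number gives the one hint available.

On that hint the step from compound 2 to compound 3 is expected to lower the number, with a size of about a 3.1-fold lower number from compound 2 to compound 3 (0.49 log units; beyond the scatter). In this assay compound 3 is therefore estimated at 9000 nM, within a range of 3000 nM to 27000 nM.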

Compound 3, concentration for 50% growth inhibition: 31800 nM
The estimate for compound 3 lay 3.5-fold (0.55 log units) below the measured number; the measured number lies above the stated range.
By their numbers in this assay, from the lowest: compound 1; then compounds 2 and 3 (each within the scatter of the next).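

In this assay, sulfamoyl in place of hydrogen, on the ring position para to a large group, gives a 1.1-fold higher number from compound 2 to compound 3 (0.06 log units; within the scatter) on the shared core of compounds 2 and 3, so on this core the added group leaves no difference that can be told from the scatter. Within the data shown here, the swap of the six-membered aromatic ring of carbon only in compound 1 for the six-membered non-aromatic ring of carbon only in compound 3, with sulfamoyl present in both, gives a 6.3-fold higher number from compound 1 to compound 3 (0.80 log units; beyond the scatter) and is the only single-place change here that goes beyond the scatter, which points to that ring rather than to sulfamoyl as the place where the number responds in this small set. No measurement at hand explains either of these two results.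

On these data alone, whether sulfamoyl in place of hydrogen counts for as little on the core of compound 1 as it does on the shared core of compounds 2 and 3 remains open. Also open, as far as these compounds go, is how the number would respond to a different group at the same ring position, such as a carboxylic acid or an amine.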